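A few compounds are considered here, and "the series" means these few. Any claim that something is new, unique, unknown or untested is made for them only; others in the source may bear on it.

Compound 1 `COc1ccc(C(=O)/C=C/c2cc3ccccc3[nH]c2=O)cc1` gives 3410 nM in a functional assay on RXF 393 cells (Homo sapiens) for cytotoxicity, read by sulforhodamine B assay, with a stated time of 24 h; a lower number here means a stronger inhibitor of growth, a higher number a weaker inhibitor of growth.
Compound 2 `O=C(/C=C/c1cc2ccccc2[nH]c1=O)c1ccc(O)cc1` gives 1650 nM in this assay.

In this assay compound 2 stands at the lowest of the two numbers; nearest is compound 1, separated by a 2.1-fold lower number from compound 1 to compound 2 (0.32 log units; beyond the scatter). Compound 3 `O=C(/C=C/c1cc2ccccc2[nH]c1=O)c1ccc(Cl)cc1` differs from compound 2 by chloro in place of hydroxy on an aromatic carbon. Within the data shown here, no measured step swaps hydroxy for chloro; the only step known, a 2.1-fold lower number from compound 1 to compound 2 (0.32 log units; beyond the scatter), concerns hydrogen in place of methyl on an oxygen and bears only indirectly. A small step, within or just beyond the scatter, is expected in this assay, direction uncertain. Compound 3 is therefore estimated at 2000 nM, between 700 nM and 6000 nM, a step of a 1.2-fold higher number from compound 2 to compound 3 (0.08 log units; within the scatter).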

Compound 3, concentration for 50% growth inhibition: 4320 nM
For compound 3 the middle estimate is 2.2-fold (0.33 log units) below the measured one; low and high end bracket the measured number.
By their numbers in this assay, from the lowest: compound 2; then compounds 1 and 3 (each within the scatter of the next).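

Replacing 4-hydroxyphenyl with 4-chlorophenyl gives a 2.6-fold higher number from compound 2 to compound 3 (0.42 log units; beyond the scatter) in this assay, so at this place chloro does not match hydroxy. Among these compounds, the comparison with the methoxy group gives a 1.3-fold higher number from compound 1 to compound 3 (0.10 log units; within the scatter) and does not separate chloro from methoxy, leaving hydroxy as the only one of the three groups that stands apart. Nothing available here explains this difference.

As far as these compounds go, whether an amine, a carboxylic acid or a longer chain at this place would give a lower or higher number stays open. So does whether any group could improve on hydroxy.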